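The compounds below may be only part of what the source reports. "The series", "measured", "known", "first", "only" and "open" are said of these compounds alone.

Measured compounds in an assay on isolated protein for binding affinity to corticotropin-releasing factor receptor 1 (Homo sapiens); on this read-out lower numbers stand for stronger inhibition and higher numbers for weaker inhibition:
- compound 1 `CCCN(CCC)c1cc(C)nc2c(-c3ncc(C)cc3[N+](=O)[O-])c(C)nn12`: 14 nM
- compound 2 `CCCN(CCC)c1cc(C)nc2c(-c3ncc(N=O)cc3C)c(C)nn12`: 100 nM

Compound 1 gives the lowest of the two numbers in this assay. Compound 2 gives a number that lies well above it, and the two structures differ in more than one place, so only the two values themselves can be compared here; nothing further is to be read from that pair.

Compound 3 `CCCN(CCC)c1cc(C)nc2c(-c3ncc(C)cc3N(C)C)c(C)nn12` is not yet measured in this assay. Compared with compound 1 it carries dimethylamino in place of nitro on an aromatic carbon, that is, dimethylamino in place of nitro on an aromatic carbon, the position being ortho to a large group, two atoms from the ring nitrogen and meta to a methyl group. Within the data shown here, no measured pair in this set shows the same change, so the size of the step is open. The expectation is a step of modest size at most, if anything toward a higher number than compound 1, with no change beyond the scatter the likeliest outcome, which for the step from compound 1 to compound 3 means an estimated 1.6-fold higher number from compound 1 to compound 3 (0.20 log units; within the scatter). In this assay compound 3 is therefore expected at about 22 nM, with a range from 5 nM to 90 nM.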

Compound 3, inhibition constant: 23 nM
The estimate for compound 3 lay 1.0-fold (0.02 log units) below the measured number, and the stated range covers the measured number.
By their numbers in this assay, from the lowest: compounds 1 and 3 (each within the scatter of the next); then compound 2.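

In this assay, dimethylamino in place of nitro on an aromatic carbon gives a 1.6-fold higher number from compound 1 to compound 3 (0.22 log units; within the scatter) and so leaves compound 1 and compound 3 indistinguishable on this read-out. Among these compounds, this is the first readable step at the position ortho to a large group, two atoms from the ring nitrogen and meta to a methyl group: two groups with the same count of heavy atoms, but with different atoms and with hydrogen-bond acceptor counts of two for nitro and one for dimethylamino, give values within the scatter of each other. No measurement here bears on why these two groups give such close values.

From the compounds shown here alone, how far this holds for other groups on the same aromatic carbon remains open, since a primary amine, a carboxylic acid or a longer chain such as diethylamino would each test it beyond this single pair. Compound 2 differs from compound 1 and compound 3 in more than one place, so the steps to it cannot be read and its value adds nothing about this position.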